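Swapping the hydroxyphenyl for a naphthyl on the amide

A few compounds are considered here, and "the series" means these few. Any claim that something is new, unique, unknown or untested is made for them only; others in the source may bear on it.

All three measured compounds share one core, seen in compound 1 `O=C(NO)c1ccc(CNc2nccc(-c3cccnc3)n2)cc1`. In an assay on isolated protein for inhibition of protein deacetylase HDAC6 (Homo sapiens), read by fluorescence, with stated times of 3 h and 60 min (a higher number here means a weaker inhibitor, a lower number a stronger inhibitor), compound 1 gives 42 nM. Compound 2 `Nc1cc(O)ccc1NC(=O)c1ccc(CNc2nccc(-c3cccnc3)n2)cc1` carries a 2-amino-4-hydroxyphenyl in place of the hydroxy on the amide-type nitrogen. In this assay compound 2 reaches only a limit of the assay, > 20000 nM, so no number is known for it. The step of an at least 470-fold higher number from compound 1 to compound 2 (2.67 log units; beyond the scatter) is large. Compound 3 `CC(C)(C)[Si](C)(C)OCc1ccc(NC(=O)c2ccc(CNc3nccc(-c4cccnc4)n3)cc2)c(N)c1` also sits at a limit in this assay, > 20000 nM. Hence the step that the two limits leave unreadable from compound 2 to compound 3 cannot be read; what can be seen is the limit of > 20000 nM in this assay, at which 2 of the 3 values shown sit.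

Compound 4 `Nc1cc2ccccc2cc1NC(=O)c1ccc(CNc2nccc(-c3cccnc3)n2)cc1` has not yet been measured. It differs from compound 2 by a group of 11 heavy atoms (10 carbon, 1 nitrogen; 2 six-membered aromatic rings of carbon only) in place of a group of 8 heavy atoms (6 carbon, 1 nitrogen, 1 oxygen; one six-membered aromatic ring of carbon only), on an amide-type nitrogen. Within the data shown here, the only measured step touching this amide-type nitrogen is an at least 470-fold higher number from compound 1 to compound 2 (2.67 log units; beyond the scatter), which moved the number from a clear value up to the limit; the other step on this side of the amide gave no readable size. Both measured compounds that carry an aromatic group on this amide-type nitrogen sit at the limit, so compound 4 is expected to stay near it, and the expected step is a number no higher from compound 2 to compound 4 (the limit leaves the size open), nothing beyond the scatter. The value estimated for compound 4 in this assay is 20000 nM, with a range from 4000 nM to 60000 nM.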

Compound 4, half-maximal inhibitory concentration: > 20000 nM
Compound 4: only a limit was reported; the forecaster's own chance of this, stated with the estimate: 70%; the middle value sits exactly at the limit.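

In this assay compound 4 reaches only a limit of the assay, > 20000 nM, which is not a number. Putting this group with 2 six-membered aromatic rings of carbon only on the amide-type nitrogen, in place of the oxygen of the hydroxy, gives an at least 470-fold higher number from compound 1 to compound 4 (2.67 log units; beyond the scatter), so a second kind of aromatic group there, differing from the 2-amino-4-hydroxyphenyl, also loses the clear value of the hydroxy compound. The steps among the compounds at the limit cannot be read, so these aromatic groups cannot be ranked against each other, but all the shown compounds with an aromatic group on this nitrogen now end in the same place, and none goes against this: the limit of > 20000 nM in this assay, at which 3 of the 4 values shown sit.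

The compounds shown leave open what happens with small groups on this nitrogen, such as a methoxy or a plain amine in place of the hydroxy, and so whether the hydroxy itself is needed for a clear value. They also leave open whether a plain phenyl, without the amino and hydroxy groups, would give a readable number.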